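A few compounds are considered here, and "the series" means these few. Any claim that something is new, unique, unknown or untested is made for them only; others in the source may bear on it.

Three ureas built on one shared core have been measured in a functional assay on NCI-H460 cells (Homo sapiens) for cytotoxicity, read by MTT assay, with a stated time of 72 h; on this read-out higher numbers stand for weaker inhibition and lower numbers for stronger inhibition. Compound 1 `CN(C)CCn1cnnc1-c1cc(Oc2ccc(NC(=O)N/N=C/c3ccc(F)cc3F)cc2F)ccn1` gives 1930 nM, and compound 2 `CN(C)CCn1cnnc1-c1cc(Oc2ccc(NC(=O)N/N=C/c3ccc(O)c(O)c3)cc2F)ccn1` gives 1930 nM; the step of no change at the digits printed from compound 1 to compound 2 (within the scatter) shows no separation between them. Compound 3 `CN(C)CCn1cnnc1-c1cc(Oc2ccc(NC(=O)N/N=C/c3ccc(O)cc3O)cc2F)ccn1` gives 11300 nM, the highest of the three numbers, and it stands apart from both of the others, as the steps of a 5.9-fold higher number from compound 1 to compound 3 (0.77 log units; beyond the scatter) and a 5.9-fold higher number from compound 2 to compound 3 (0.77 log units; beyond the scatter) show. The next compound, compound 4 `CN(C)CCn1cnnc1-c1cc(Oc2ccc(NC(=O)N/N=C/c3cccc(O)c3)cc2F)ccn1`, differs from compound 3 by 3-hydroxyphenyl in place of 2,4-dihydroxyphenyl on a carbon with a double bond to nitrogen. For the measured compounds named here, no measured step removes a hydroxyl in this way, so the bearing is indirect: the step of a 5.9-fold higher number from compound 2 to compound 3 (0.77 log units; beyond the scatter) shows a modest cost on going from 3,4-dihydroxyphenyl to 2,4-dihydroxyphenyl, and a 5.9-fold higher number from compound 1 to compound 3 (0.77 log units; beyond the scatter) shows the same cost starting from 2,4-difluorophenyl. Compound 4 is therefore expected to move back toward the numbers of compound 1 and compound 2, with an estimated step of a 3.8-fold lower number from compound 3 to compound 4 (0.58 log units; beyond the scatter) in this assay. Compound 4 is estimated at 3000 nM, expected to fall between 1000 nM and 9000 nM.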

Compound 4, half-maximal inhibitory concentration: 780 nM
For compound 4 the middle estimate is 3.8-fold (0.59 log units) above the measured one, and the stated range ends above it.
By their numbers in this assay, from the lowest: compound 4; then compounds 1 and 2 (each within the scatter of the next); then compound 3.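

On the carbon with a double bond to nitrogen, 3-hydroxyphenyl gives the lowest number of the four in this assay: a 14-fold lower number from compound 3 to compound 4 (1.16 log units; beyond the scatter) is a large step, while a 2.5-fold lower number from compound 2 to compound 4 (0.39 log units; beyond the scatter) and a 2.5-fold lower number from compound 1 to compound 4 (0.39 log units; beyond the scatter) are modest steps, both beyond the scatter. For the compounds shown here, a single hydroxyl on this ring is therefore enough for the lowest number so far, and the count of hydroxyls does not order the series, since compound 1, with none, and compound 2, with two, print the same value. Nothing available here explains these differences.

On these data alone, how an unsubstituted phenyl, a 3-methoxyphenyl or a 3-aminophenyl would stand at this place remains open. The share of the hydroxyl itself in the result for compound 4 therefore cannot yet be told.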